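Changing the chain end of compound 3

The compounds below may be only part of what the source reports. "The series", "measured", "known", "first", "only" and "open" are said of these compounds alone.

Measured in a functional assay for inhibition, with Homo sapiens as the target; on this read-out lower numbers stand for stronger inhibition and higher numbers for weaker inhibition:
- Compound 1 `O=C(O)CCCCCCCCn1nc(-c2ccccc2)c(-c2ccccc2)c1-c1ccccc1`: 400 nM
- Compound 2 `O=C(O)CCCCCCCCCCn1nc(-c2ccccc2)c(-c2ccccc2)c1-c1ccccc1`: 18600 nM
- Compound 3 `O=C(O)CSCCCCCCn1nc(-c2ccccc2)c(-c2ccccc2)c1-c1ccccc1`: 870 nM

Compound 3 holds the middle of these three numbers, above compound 1 and below compound 2. Compound 4 `NC(=O)CCCCCCCCn1nc(-c2ccccc2)c(-c2ccccc2)c1-c1ccccc1` has 2-carbamoylethyl in place of (carboxymethyl)sulfanyl, on a saturated chain carbon, six bonds along the chain from an aromatic nitrogen (2-carbamoylethyl in place of (carboxymethyl)sulfanyl on a saturated chain carbon, six bonds along the chain from an aromatic nitrogen). Two measured steps offer some guidance. The modest 2.2-fold higher number from compound 1 to compound 3 (0.34 log units; beyond the scatter) involved (carboxymethyl)sulfanyl at this place. The large 47-fold higher number from compound 1 to compound 2 (1.67 log units; beyond the scatter) shows that one chain change can move the number sharply. Among the measured compounds shown here, no measured compound carries a carbamoyl group, so that part remains untested. The expected result in this assay is a large move towards weaker inhibition, estimated as a 9.2-fold higher number from compound 3 to compound 4 (0.96 log units; beyond the scatter). For compound 4 the estimate is 8000 nM, with a range of 1500 nM to 40000 nM.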

Compound 4, half-maximal inhibitory concentration: 33000 nM
Estimate against measurement, compound 4: 4.1-fold (0.62 log units) below; low and high end bracket the measured number.
By their numbers in this assay, from the lowest: compound 1; then compound 3; then compounds 2 and 4 (each within the scatter of the next).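

The acid end counts at this chain length: in this assay, amino in place of hydroxy on the carbonyl carbon gives an 83-fold higher number from compound 1 to compound 4 (1.92 log units; beyond the scatter), and the (carboxymethyl)sulfanyl chain end also stands well clear of the amide, with a 38-fold higher number from compound 3 to compound 4 (1.58 log units; beyond the scatter). Removing the acid and lengthening the chain end up alike, with a 1.8-fold higher number from compound 2 to compound 4 (0.25 log units; within the scatter). Nothing given here offers a reason for these steps. Still open, going by these compounds, is whether a methyl ester, a tetrazole or an amine at the chain end would keep the inhibition of compound 1. Also open, on these data alone, is how the amide behaves on a shorter chain.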